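A few compounds are considered here, and "the series" means these few. Any claim that something is new, unique, unknown or untested is made for them only; others in the source may bear on it.

Compound 1 `CC(O)(CS(=O)(=O)c1ccc(Br)cc1)c1nc(-c2ccc([N+](=O)[O-])c(C(F)(F)F)c2)no1` was tested in a functional assay on DU-145 cells (Homo sapiens) for cytotoxicity, read by MTT assay; on this read-out higher numbers stand for weaker inhibition and lower numbers for stronger inhibition. Compound 1 gives > 100000 nM, which is a limit of the assay rather than a number. Compound 2 `CC(O)(CSc1ccc(Br)cc1)c1nc(-c2ccccc2)no1` was examined in the same way; in this assay compound 2 gives > 100000 nM, again a limit of the assay. Compound 1 therefore stands where every value shown stands, at the limit of > 100000 nM in this assay, at which 2 of the 2 values shown sit. Compound 3 `CC(O)(CSc1ccc(Cl)cc1)c1nc(-c2ccc([N+](=O)[O-])c(C(F)(F)F)c2)no1` has not yet been measured. It differs from compound 1 by (4-chlorophenyl)sulfanyl in place of (4-bromophenyl)sulfonyl on a saturated chain carbon, two bonds along the chain from an aromatic carbon and an oxygen on a saturated carbon. Because compound 2 with its sulfanyl link to a halogenated ring gives > 100000 nM in this assay, no step beyond the usual scatter is expected from this change. The step from compound 1 to compound 3 is estimated as a number no higher from compound 1 to compound 3 (the limit leaves the size open). Compound 3 is estimated at 100000 nM, within 30000 nM to 300000 nM, and is expected most likely to be reported only as a limit.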

Compound 3, half-maximal inhibitory concentration: 1300 nM
For compound 3 the middle estimate is 77-fold (1.89 log units) above the measured one, and the stated range ends above it.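

In this assay, placing (4-chlorophenyl)sulfanyl where (4-bromophenyl)sulfonyl stood gives an at least 76-fold lower number from compound 1 to compound 3 (1.88 log units; beyond the scatter), so the group at this place on the saturated chain can decide whether a measurable value appears at all. Going by these compounds alone, compound 3 is the first compound here to give a number rather than a limit, and the true step may be larger than the one printed, since its starting point is only a limit. Even so, the limit remains the most common result so far: the limit of > 100000 nM in this assay, at which 2 of the 3 values shown sit.

This one change swaps the sulfonyl link for a sulfanyl link and bromine for chlorine together, so the compounds shown cannot tell which of the two carries the step. Going by these compounds, a (4-chlorophenyl)sulfonyl group at this place would help separate them, and what an amine in place of the sulfur link would do also stays open.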